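The source may hold more compounds than are shown below. What is called first, only, known or untested is meant among the compounds shown, and "the series" means these compounds.

Two members of the series have numbers in an assay on SH-EP1 cells for agonist activity at Neuronal acetylcholine receptor; alpha4/beta2 (Homo sapiens), read by FLIPR and calcium flux (a lower number here means a smaller maximal response, a higher number a larger maximal response), so far. Compound 1, `O=C(C1CC=CC1)N1CC2CC(C1)N2`, carries a cyclopentenyl group on the carbonyl and gives in this assay 93%. Compound 2, `O=C([C@H]1C[C@H]1F)N1CC2CC(C1)N2`, carries a 2-fluorocyclopropyl group there and gives in this assay 110%. On these two numbers compound 2 stands highest, with compound 1 the nearest and lower by a gap that lies beyond the usual scatter of the measurement.

The next member is compound 3, `C[C@H]1C[C@@H]1C(=O)N1CC2CC(C1)N2`, not yet measured in this assay. It differs from compound 2 in one place: 2-methylcyclopropyl in place of 2-fluorocyclopropyl on a carbonyl carbon. The three-membered ring and the amide are kept; only the substituent on that ring is exchanged, with no change in donors, acceptors or charge.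

With no comparable exchange available among measured pairs, the step is expected to be small, within the scatter, perhaps slightly downward: from compound 2 to compound 3 the change is estimated as a number 8 percentage points lower from compound 2 to compound 3 (within the scatter). The maximal response of compound 3 in this assay is therefore expected near 102%, with a range from 82% to 120%.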

Compound 3, largest response reached (Emax), in percent of the reference or control that the assay uses: 67%
For compound 3 the middle estimate is 35 percentage points above the measured one; measured number below the stated range.
By their numbers in this assay, from the lowest: compound 3; then compound 1; then compound 2.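

In this assay, within the data shown here, 2-methylcyclopropyl in place of 2-fluorocyclopropyl on a carbonyl carbon amounts to a number 43 percentage points lower from compound 2 to compound 3 (beyond the scatter), the only step so far that can be read at a single place, and it is large. The two groups match in heavy-atom count, in the three-membered carbon ring, in having no hydrogen-bond donors or acceptors, and in carrying no net charge, so this position is shown to be sensitive to the exchange of fluorine for methyl on that ring alone, with the maximal response not set by the ring and amide that the two compounds share. Nothing measured here bears on the reason for the fall.

Open, going by these compounds, is whether the fall belongs to methyl itself or whether fluorine is the exception: a cyclopropyl ring with no substituent, or one bearing chlorine, hydroxymethyl or trifluoromethyl, would place both groups on a wider scale. Also open, on these data alone, is whether a step of this size would persist with a longer chain on the ring, such as ethyl or propyl, on the same shared core.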